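A Hydroxy Group Added to Compound 3

The source may hold more compounds than are shown below. What is called first, only, known or untested is meant among the compounds shown, and "the series" means these compounds.

In a functional assay on NCI-H460 cells (Homo sapiens) for cytotoxicity, read by MTT assay, with a stated time of 72 h (on this read-out higher numbers stand for weaker inhibition and lower numbers for stronger inhibition), compound 3 `Cc1ccc(/C=c2\[nH]c(=O)/c(=C/c3cccc(Oc4ccc(F)cc4)c3)[nH]c2=O)o1` gives 30 nM. Compound 1 `Cc1[nH]cnc1/C=c1\[nH]c(=O)/c(=C/c2cccc(Oc3ccc(F)cc3)c2)[nH]c1=O` gives 47.6 nM. That is a 1.6-fold lower number from compound 1 to compound 3 (0.20 log units; within the scatter), so the two stand level. Compound 2 `O=c1[nH]/c(=C\c2ccc([N+](=O)[O-])o2)c(=O)[nH]/c1=C\c1cccc(Oc2ccc(F)cc2)c1` reads > 1000 nM, which is a limit of the assay and not a number.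

Compound 4 `O=c1[nH]/c(=C\c2ccc(CO)o2)c(=O)[nH]/c1=C\c1cccc(Oc2ccc(F)cc2)c1` carries one change, hydroxy in place of hydrogen on a saturated chain carbon bound to an aromatic carbon, which turns methyl to hydroxymethyl (hydroxy in place of hydrogen on a saturated chain carbon bound to an aromatic carbon). The nearest measured evidence is an at least 33-fold lower number from compound 2 to compound 3 (1.52 log units; beyond the scatter), where methyl replaces nitro. That large step shows the group can matter, but it is a different swap and sets no size here.

The expected step is a 1.8-fold higher number from compound 3 to compound 4 (0.26 log units; within the scatter), a slight move to a higher number. For compound 4 the estimated value is 55 nM, within an expected range of 18 nM to 200 nM.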

Compound 4, half-maximal inhibitory concentration: 41.5 nM
For compound 4 the middle estimate is 1.3-fold (0.12 log units) above the measured one; the measured number falls inside the stated range.
By their numbers in this assay, from the lowest: compounds 3, 4 and 1 (each within the scatter of the next). At a limit, above all of these: compound 2.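

Hydroxy in place of hydrogen on this saturated chain carbon leaves the read-out level, a 1.4-fold higher number from compound 3 to compound 4 (0.14 log units; within the scatter), so this position accepts hydroxymethyl as well as methyl, and the furan stays level with the imidazole, a 1.1-fold lower number from compound 1 to compound 4 (0.06 log units; within the scatter). Of the groups shown at this end of the molecule, only nitro stands far off, an at least 24-fold lower number from compound 2 to compound 4 (1.38 log units; beyond the scatter). Compound 2 reads at a limit of the assay, so that step is a bound and not a size: the limit of > 1000 nM in this assay, at which 1 of the 4 values shown sits.

As far as these compounds go, what an amine or a carboxylic acid in place of the hydroxy would give stays open. So does the effect of a longer chain carrying the hydroxy.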